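Chlorophenyl in place of thiophen-3-yl on a shared core

A few compounds are considered here, and "the series" means these few. Any claim that something is new, unique, unknown or untested is made for them only; others in the source may bear on it.

Compound 2 `c1cn2cc(-c3ccsc3)nc(-c3ccc4ncn(C5CCCCC5)c4c3)c2n1` was tested in a functional assay on NCI-H23 cells (Homo sapiens) for inhibition, read by sulforhodamine B assay, with a stated time of 48 h, tested at 10 uM (a lower number here means less inhibition, a higher number more inhibition at the concentration tested (going by the name of the read-out)), and gives 10%. Compound 1 `c1ccc2c(-c3cn4ccnc4c(-c4ccc5ncn(C6CCCCC6)c5c4)n3)cccc2c1` gives 4.32% in this assay, and the step of a number 5.7 percentage points higher from compound 1 to compound 2 (within the scatter) lies within the scatter, so the two numbers cannot be told apart. Compound 3 `Clc1ccc(-c2cn3ccnc3c(-c3ccc4ncn(C5CCCCC5)c4c3)n2)cc1` differs from compound 2 as follows: 4-chlorophenyl in place of thiophen-3-yl on an aromatic carbon. Among the measured compounds shown here, only that one measured step bears on this change, and it was small; no measured step brings in 4-chlorophenyl. The expectation is therefore no step beyond the scatter in this assay, and compound 3 is estimated at 10%, between 0% and 25%, an expected step of no change at the digits printed from compound 2 to compound 3 (within the scatter).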

Compound 3, a percentage reported as inhibition, at one concentration (the size of the read-out at that concentration, not a potency): 4.11%
The estimate for compound 3 lay 5.9 percentage points above the measured number, and the stated range covers the measured number.
By their numbers in this assay, from the lowest: compounds 3, 1 and 2 (each within the scatter of the next).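

In this assay the 4-chlorophenyl group gives a number 5.9 percentage points lower from compound 2 to compound 3 (within the scatter) when it replaces thiophen-3-yl and a number 0.2 percentage points lower from compound 1 to compound 3 (within the scatter) when it replaces naphthalen-1-yl on this aromatic carbon. Three different aromatic groups at this position, now including a six-membered aromatic ring of carbon only that carries chlorine, thus cannot be told apart in this read-out. As far as these compounds go, whether an amine, a carboxylic acid or a morpholine on this carbon would give a step beyond the scatter stays open. No independent evidence bears on this result.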